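The source may report more compounds than this note shows. Statements on the series, on what has been measured and on what is new or still open speak of the compounds shown alone.

Of the compounds shown here, three have been tested in an ADME assay on HEK293 cells (Homo sapiens) for cytotoxicity, read by CellTiter-Glo and resazurin assay, with a stated time of 72 h; a higher number here means that more compound is needed for the effect, a lower number that less compound is needed. Compound 1 `CC(C)N(Cc1cccc(OCCCCCC(=O)O)c1)C(=O)c1ccc(-c2cccc(Oc3ccccc3)c2)cc1` carries a phenoxy group and a free carboxylic acid; in this assay compound 1 reaches only the limit of > 18700 nM. Compound 2 `CC(C)N(Cc1cccc(OCCCCCC(=O)O)c1)C(=O)c1ccc(-c2cccc(OCc3ccccc3)c2)cc1` differs from compound 1 in that (benzyl in place of phenyl on an oxygen on an aromatic ring); in this assay compound 2 likewise stops at the limit of > 26000 nM. The two limits the limit of > 18700 nM in this assay, at which 1 of the 3 values shown sits, and the limit of > 26000 nM in this assay, at which 1 of the 3 values shown sits, leave the step that the two limits leave unreadable from compound 1 to compound 2 unreadable. Compound 3 `CCOC(=O)CCCCCOc1cccc(CN(C(=O)c2ccc(-c3cccc(Oc4ccccc4)c3)cc2)C(C)C)c1` differs from compound 1 in that (ethyl in place of hydrogen on an oxygen next to a carbonyl group); in this assay compound 3 gives only the limit of > 19600 nM. The step that the two limits leave unreadable from compound 1 to compound 3 is left unreadable in the same way by the two limits the limit of > 18700 nM in this assay, at which 1 of the 3 values shown sits, and (the limit of > 19600 nM in this assay, at which 1 of the 3 values shown sits). Compound 4 `CCOC(=O)CCCCCOc1cccc(CN(C(=O)c2ccc(-c3cccc(OCc4ccccc4)c3)cc2)C(C)C)c1` has not yet been measured; it differs from compound 3 in that (benzyl in place of phenyl on an oxygen on an aromatic ring), the same change that separates compound 1 from compound 2, made at the same place. That earlier step could not be read, so the expectation for compound 4 rests instead on all three measured compounds sitting at a limit. Compound 4 is therefore expected to show a step that the limit leaves unreadable from compound 3 to compound 4 and an estimated value near 30000 nM, most likely reported again as a limit.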

Compound 4, half-maximal effective concentration: > 26000 nM
Compound 4 was reported as a limit; the forecaster's own chance of this, stated with the estimate: 85%; the middle value does not contradict the limit.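

Compound 4 is also reported only as a limit, > 26000 nM, so neither its step from compound 3 nor its step from compound 2 can be read. The four compounds shown leave open the concentration at which any of them reaches the half-maximal effect, and whether either change, benzyl for phenyl or ethyl for hydrogen, alters it.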